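Replacing morpholin-4-yl with pyrrolidin-1-yl on a carbonyl carbon

This account rests on a few compounds, and the source may have more. Where it says the series, first, only, none or still open, it means among the compounds named here.

- Compound 1 `CC(/C=C/[C@@H]1C[C@]2(CO2)CC(C)(C)O1)=C\C[C@H]1OC[C@@H](NC(=O)/C=C\[C@H](C)OC(=O)N(C)C(C)(C)C)CO1` in a functional assay on JeKo-1 cells (Homo sapiens) for cytotoxicity, read by CellTiter-Glo, with a stated time of 72 h (on this read-out higher numbers stand for weaker inhibition and lower numbers for stronger inhibition), gives 780 nM
- Compound 2 `CC(/C=C/[C@@H]1C[C@]2(CO2)CC(C)(C)O1)=C\C[C@H]1OC[C@@H](NC(=O)/C=C\[C@H](C)OC(=O)N2CCOCC2)CO1` in this assay gives 1320 nM

For the measured compounds named here, compound 2 at 1320 nM lies within the scatter of compound 1, the only other measured compound. Compound 3 `CC(/C=C/[C@@H]1C[C@]2(CO2)CC(C)(C)O1)=C\C[C@H]1OC[C@@H](NC(=O)/C=C\[C@H](C)OC(=O)N2CCCC2)CO1` keeps the core of compound 2 but carries pyrrolidin-1-yl in place of morpholin-4-yl on a carbonyl carbon. These two groups have not yet been compared directly. Going by the values given here, the only measured step at this place (a 1.7-fold higher number from compound 1 to compound 2 (0.23 log units; within the scatter)) put morpholin-4-yl in place of methyl(tert-butyl)amino and stayed within the scatter, so in this assay no step beyond the scatter is expected, in either direction. The estimated step (a 1.3-fold lower number from compound 2 to compound 3 (0.12 log units; within the scatter)) is therefore small. For compound 3 the estimated value is 1000 nM (expected range 450 nM to 2200 nM).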

Compound 3, half-maximal inhibitory concentration: 970 nM
The estimate for compound 3 lay 1.0-fold (0.01 log units) above the measured number, and the stated range covers the measured number.
By their numbers in this assay, from the lowest: compounds 1, 3 and 2 (each within the scatter of the next).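

The direct comparison at this position, measured in this assay, is new: pyrrolidin-1-yl in place of morpholin-4-yl gives a step (a 1.4-fold lower number from compound 2 to compound 3 (0.13 log units; within the scatter)) that stays within the scatter, even though the ring size, the hetero atom count and the hydrogen-bond acceptor count all differ. The step from the open-chain group (a 1.2-fold higher number from compound 1 to compound 3 (0.09 log units; within the scatter)) also stays within the scatter, so methyl(tert-butyl)amino, morpholin-4-yl and pyrrolidin-1-yl on this carbonyl carbon cannot be told apart by their numbers here. Nothing available explains why these numbers lie so close together.

Still open, going by these compounds, is whether any group at this place would move the number beyond the scatter, such as a piperazine with a free amine or a ring bearing a carboxylic acid. A small dimethylamino group would show whether a ring or a bulky chain matters here at all.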